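This account rests on a few compounds, and the source may have more. Where it says the series, first, only, none or still open, it means among the compounds named here.

Of the compounds shown here, three have been measured and a fourth is still open. Compound 1 `CC1(C)CC(C)(C)c2cc(NC(=S)Nc3ccc(S(N)(=O)=O)cc3)ccc2O1` gives 6900 nM in a functional assay on A2780 cells (Homo sapiens) for inhibition, with a stated time of 72 h; a lower number here means a stronger inhibitor, a higher number a weaker inhibitor. Compound 2 `CC1(C)CCOc2ccc(NC(=S)Nc3ccc(OC(F)(F)F)cc3)cc21` gives 4300 nM in this assay, and compound 3 `CC1(C)CC(C)(C)c2cc(NC(=O)Nc3ccc(C#N)cc3)ccc2O1` gives 4700 nM in this assay. On these three numbers compound 3 stands second highest, and its gaps to compound 2 and to compound 1 both lie within the usual scatter, so the three are not separated. Compound 4 `CC1(C)CC(C)(C)c2cc(NC(=O)Nc3ccc(OC(F)(F)F)cc3)ccc2O1` differs from compound 3 by trifluoromethoxy in place of cyano on an aromatic carbon. Compound 2 carries the same trifluoromethoxy group on a different core and gives 4300 nM, close to what compound 3 gives with 4700 nM, so no step beyond the scatter is expected in this assay. The estimated step is a 1.0-fold lower number from compound 3 to compound 4 (0.02 log units; within the scatter). Compound 4 is expected to give 4500 nM, within 2000 nM to 10000 nM.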

Compound 4, half-maximal inhibitory concentration: 4560 nM
For compound 4 the middle estimate is 1.0-fold (0.01 log units) below the measured one; low and high end bracket the measured number.
By their numbers in this assay, from the lowest: compounds 2, 4, 3 and 1 (each within the scatter of the next).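

In this assay putting trifluoromethoxy in place of cyano on this aromatic carbon, para to a large group, gives a 1.0-fold lower number from compound 3 to compound 4 (0.01 log units; within the scatter) and so does not separate the two compounds. Among the compounds shown here, this is the first direct comparison between measured compounds, and it shows that on this core, five heavy atoms can replace two at this position with no change beyond the scatter. Nothing available here explains why the two groups read alike. From the compounds shown here alone, an amine or a carboxylic acid on the same carbon remains open, so it is unknown whether this position accepts every kind of group or only some.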